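Dropping the Drawn Configuration at a Ring Stereocentre

The source may report more compounds than this note shows. Statements on the series, on what has been measured and on what is new or still open speak of the compounds shown alone.

Compound 1 `Fc1cccc(-c2cn(C3CN4CCC3CC4)nn2)c1` and compound 2 `FCCCOc1cccc(-c2cn([C@@H]3CN4CCC3CC4)nn2)c1` share the same core and were both tested in an assay on HEK293 cells for displacement of a labelled ligand from Neuronal acetylcholine receptor; alpha4/beta2 (Homo sapiens), read by scintillation counting, with a stated time of 120 min; a lower number here means a stronger inhibitor, a higher number a weaker inhibitor. In this assay compound 1 gives 748 nM, and compound 2 gives 1980 nM, so compound 2 holds the higher of the two numbers, and its gap to compound 1 lies beyond the usual scatter. Compound 3 `FCCCOc1cccc(-c2cn(C3CN4CCC3CC4)nn2)c1` is the next member of the set. It differs from compound 2 as follows: the two compounds have the same atoms and bonds; at least one stereo element is drawn with a configuration in one of them and without one in the other: 1 of 3 stereo elements differ; a stereocentre at a saturated ring carbon is drawn S in compound 2 and without a configuration in compound 3. Among the measured compounds shown here, no step between two measured compounds covers a change of this kind, so the size of the step can only be weighed against the value of compound 2 itself. Compound 3 keeps every atom and bond of compound 2 and merely lacks the drawn configuration at the stereocentre at a saturated ring carbon. Compound 3 is therefore expected to give 2800 nM in this assay, with a range of 1200 nM to 7000 nM. The expected step of a 1.4-fold higher number from compound 2 to compound 3 (0.15 log units; within the scatter) is modest and, if anything, toward a weaker inhibitor.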

Compound 3, inhibition constant: 3890 nM
Estimate against measurement, compound 3: 1.4-fold (0.14 log units) below, within the range that was stated.
By their numbers in this assay, from the lowest: compound 1; then compounds 2 and 3 (each within the scatter of the next).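

Removing the drawn configuration at the stereocentre at a saturated ring carbon gives a 2.0-fold higher number from compound 2 to compound 3 (0.29 log units; within the scatter) in this assay, so the form drawn S and the form drawn without a configuration cannot be told apart in this assay. Among the compounds shown here, with that carbon now drawn alike on both sides, 3-fluoropropoxy in place of fluoro on an aromatic carbon can be read on its own for the first time, as a 5.2-fold higher number from compound 1 to compound 3 (0.72 log units; beyond the scatter). The comparison at the stereocentre rests on a single difference in how the structures are drawn: the fact that one of compounds 2 and 3 is drawn with a defined configuration and the other without, at the place where they differ

As far as these compounds go, what compound 3 actually holds at that carbon stays open, as does how a form drawn R would read. Also open, from the compounds shown here alone, is how a hydroxyl group or a plain propoxy chain in place of the 3-fluoropropoxy would compare with fluoro.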